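From anilino to amino: a step not yet measured

This account rests on a few compounds, and the source may have more. Where it says the series, first, only, none or still open, it means among the compounds named here.

In a functional assay on SF-268 cells (Homo sapiens) for antiproliferative activity, read by sulforhodamine B assay, with a stated time of 72 h (a higher number here means a weaker inhibitor, a lower number a stronger inhibitor), compound 1 `S=C(NNc1nncc2ccccc12)Nc1ccccc1` gives 57 nM
Compound 2 `COc1ccc(NC(=S)NNc2nncc3ccccc23)cc1` gives 86 nM
Compound 3 `NC(=S)NNc1nncc2ccccc12` has not yet been measured

Within the data shown here, compound 1 stands level with compound 2, the only other measured compound. Their step is a 1.5-fold higher number from compound 1 to compound 2 (0.18 log units; within the scatter) for methoxy in place of hydrogen on an aromatic carbon.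

The change to compound 3 reads hydrogen in place of phenyl on an amide-type nitrogen and amounts to hydrogen in place of phenyl on an amide-type nitrogen, or anilino to amino. Among the measured compounds shown here, the one measured step keeps the phenyl, so it bears only weakly on this change, and no measured pair removes that group. A step towards a higher number in this assay beyond the scatter is expected, although its size remains uncertain. The estimated step is a 4.4-fold higher number from compound 1 to compound 3 (0.64 log units; beyond the scatter) on this reading. Compound 3 is expected at 250 nM with an estimated range from 60 nM to 1200 nM for repeated measurements.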

Compound 3, half-maximal inhibitory concentration: 17 nM
The estimate for compound 3 lay 15-fold (1.17 log units) above the measured number, outside the stated range (below it).
By their numbers in this assay, from the lowest: compound 3; then compounds 1 and 2 (each within the scatter of the next).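

In this assay, hydrogen in place of phenyl on the amide-type nitrogen gives a 3.4-fold lower number from compound 1 to compound 3 (0.53 log units; beyond the scatter) and so shows that the phenyl is not needed for activity against these cells. The earlier pair kept that ring and showed only a 1.5-fold higher number from compound 1 to compound 2 (0.18 log units; within the scatter) for methoxy in place of hydrogen on an aromatic carbon, a step that left open what the ring itself contributes; the anilino to amino change now shows that losing all of it gives a modest step towards a lower number. No measurement here bears on why the number moves this way.

The compounds shown hold only phenyl, methoxy-substituted phenyl and hydrogen at this nitrogen, so it remains open how a methyl, an ethyl or a benzyl group there would read. Going by these compounds, it also remains open whether this step would keep its direction and size on any other core.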